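Series notes: amide heteroaryl swap, compound 3 to compound 4

A few compounds are considered here, and "the series" means these few. Any claim that something is new, unique, unknown or untested is made for them only; others in the source may bear on it.

Compound 1 `CCCn1c(NC(=O)c2cc(C)nn2CC)nc2cccc(OC)c21` in an assay for activation of interferon regulatory factor 3 (Homo sapiens), read by a luciferase reporter, with a stated time of 20 h (a higher number here means that more compound is needed for the effect, a lower number that less compound is needed), gives > 100000 nM, which is a limit of the assay.
Compound 2 `CCCn1c(NC(=O)c2nccc3ccccc23)nc2cc(C(N)=O)cc(OC)c21` in this assay gives > 100000 nM, which is a limit.
Compound 3 `COc1cc(C(N)=O)cc2nc(NC(=O)c3nccc4ccccc34)n(CCCNC(=O)OCc3ccccc3)c12` in this assay gives > 100000 nM, which is a limit.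

Compound 3 therefore stands only at a limit, with no number of its own. Going by the values given here, the one single-point step among the measured compounds, a step that the two limits leave unreadable from compound 2 to compound 3, is left unreadable by the two limits, and the whole picture so far is the limit of > 100000 nM in this assay, at which 3 of the 3 values shown sit.

Compound 4 `COc1cc(C(N)=O)cc2nc(NC(=O)c3cccn3C)n(CCCNC(=O)OCc3ccccc3)c12` differs from compound 3 by 1-methyl-1H-pyrrol-2-yl in place of isoquinolin-1-yl on a carbonyl carbon. Among the compounds with values here, no measured step bears on a change of the amide heteroaryl; compound 1, which carries a different amide on the shared core, also sits at the limit. The step of a number no higher from compound 3 to compound 4 (the limit leaves the size open) is estimated as none that can be read, with the expectation that compound 4 again returns a limit.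

Compound 4 in this assay is expected at about 100000 nM, within 30000 nM to 300000 nM, most likely reported as a limit.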

Compound 4, half-maximal effective concentration: > 100000 nM
Compound 4: only a limit was reported; the forecaster's own chance of this, stated with the estimate: 80%; the middle value lies on the limit itself.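

No new step can be read between compound 3 and compound 4, as both values are limits, and the same holds across the series: the limit of > 100000 nM in this assay, at which 4 of the 4 values shown sit.

The compounds shown leave open whether any amide heteroaryl or chain substituent on the shared core gives a measurable value in this assay at all.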